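The source may hold more compounds than are shown below. What is called first, only, known or untested is meant among the compounds shown, and "the series" means these compounds.

Working notes on the series in an ADME assay on Huh-7 cells (Homo sapiens) for cytotoxicity, read by XTT assay, with a stated time of 3 days, tested at 20 uM; on this read-out lower numbers stand for a stronger effect and higher numbers for a weaker effect at the one concentration tested. Compound 3 `Fc1ccc(-c2cc(-c3ccc4cc(F)ccc4n3)n(-c3ccc(F)cc3)n2)cc1` gives 95.3% in this assay. Going by the values given here, of the three numbers so far it is the lowest, though every gap is within the scatter: compound 2 `Fc1ccc(-n2nc(-c3ccccc3)cc2-c2ccc3cc(F)ccc3n2)cc1` gives 97.8%, and compound 1 `COc1ccc(-c2cc(-c3ccc4cc(F)ccc4n3)n(-c3ccccc3)n2)cc1` gives 104%. Among the compounds with values here, the one step measured in one place, a number 2.5 percentage points lower from compound 2 to compound 3 (within the scatter), shows that exchanging hydrogen for fluoro on an aromatic carbon changes nothing beyond the scatter.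

Compound 4 `COc1ccc(-c2cc(-c3ccc4cc(F)ccc4n3)n(-c3ccc(F)cc3)n2)cc1` is not yet measured. It differs from compound 3 in one place: methoxy in place of fluoro on an aromatic carbon. Within the data shown here, no measured step covers this exact exchange. Among the measured compounds shown here, what bears on it is that compound 1, which also carries the 4-methoxyphenyl group, and compound 3, which carries fluoro at that position, sit within the scatter of each other, and the single step in this assay was itself within the scatter. The step of a number 3.7 percentage points higher from compound 3 to compound 4 (within the scatter) is therefore expected to stay within the scatter, without a clear direction. Compound 4 is estimated at 99%, with a range from 88% to 110%.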

Compound 4, a percentage reported as activity, at one concentration (the size of the read-out at that concentration, not a potency): 98.8%
Compound 4: middle estimate off by 0.2 percentage points, on the high side; the range from low to high includes it.
By their numbers in this assay, from the lowest: compounds 3, 2, 4 and 1 (each within the scatter of the next).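

The exchange of 4-fluorophenyl to 4-methoxyphenyl now has a measured step of its own (a number 3.5 percentage points higher from compound 3 to compound 4 (within the scatter)), and methoxy in place of hydrogen on the same aromatic carbon also has one (a number 1 percentage points higher from compound 2 to compound 4 (within the scatter)). In this assay, neither fluoro nor methoxy at this position therefore moves the number beyond the scatter, set against hydrogen or against each other. Fluoro in place of hydrogen can now be read on a second core (a number 5.2 percentage points lower from compound 1 to compound 4 (within the scatter)), and the two readings agree: the same change on two cores in this assay, a number 2.5 percentage points lower (within the scatter) from compound 2 to compound 3 and a number 5.2 percentage points lower (within the scatter) from compound 1 to compound 4, 2.7 percentage points apart, within the scatter of two such steps.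

Going by these compounds, whether an amine or a carboxylic acid on this aromatic carbon would also stay within the scatter remains open. The compounds shown also leave open how the series behaves at any concentration other than the one tested.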